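A few compounds are considered here, and "the series" means these few. Any claim that something is new, unique, unknown or untested is made for them only; others in the source may bear on it.

Series notes, an ADME assay on HepG2 2.2.15 cells (Homo sapiens) for cytotoxicity; a higher number here means that more compound is tolerated, a lower number that less compound is tolerated:

- compound 1 `COCC(=O)OCCc1c(-c2ccccc2Cl)c2cc(Cl)ccc2[nH]c1=O`: 74000 nM
- compound 2 `CC(=O)NCC(=O)OCCc1c(-c2ccccc2Cl)c2cc(Cl)ccc2[nH]c1=O`: 110000 nM
- compound 3 `O=C(OCCc1c(-c2ccccc2Cl)c2cc(Cl)ccc2[nH]c1=O)C1CCCCC1`: 38000 nM

Compound 1 stands second highest of the three in this assay; compound 2 sits within the scatter of it, with a 1.5-fold higher number from compound 1 to compound 2 (0.17 log units; within the scatter), and compound 3 lies below it, with a 1.9-fold lower number from compound 1 to compound 3 (0.29 log units; within the scatter), also within the scatter. The step from compound 2 to compound 3 is the only one beyond the scatter, a 2.9-fold lower number from compound 2 to compound 3 (0.46 log units; beyond the scatter).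

Compound 4 `O=C(/C=C/c1cccc(C(F)(F)F)c1)OCCc1c(-c2ccccc2Cl)c2cc(Cl)ccc2[nH]c1=O` differs from compound 1 in one place: 2-(3-(trifluoromethyl)phenyl)ethenyl in place of methoxymethyl on a carbonyl carbon. Within the data shown here, the nearest precedent is the entry of a ring in place of the methoxymethyl group, which gave a 1.9-fold lower number from compound 1 to compound 3 (0.29 log units; within the scatter), and the related 2.9-fold lower number from compound 2 to compound 3 (0.46 log units; beyond the scatter) points the same way. A modest lowering is therefore expected for compound 4 in this assay, a 2.5-fold lower number from compound 1 to compound 4 (0.39 log units; beyond the scatter), putting the expected value near 30000 nM, with a range from 12000 nM to 70000 nM.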

Compound 4, half-maximal cytotoxic concentration: > 1400000 nM
Compound 4: a limit, no number; the forecaster's own chance of this, stated with the estimate: 5%; middle value at least 46-fold (1.66 log units) away from the limit.
By their numbers in this assay, from the lowest: compounds 3, 1 and 2 (each within the scatter of the next, the first and the last beyond it). At a limit, above all of these: compound 4.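

The value for compound 4 is a limit, not a number: the limit of > 1400000 nM in this assay, at which 1 of the 4 values shown sits. On this carbonyl carbon, 2-(3-(trifluoromethyl)phenyl)ethenyl stands apart from all three earlier groups, with an at least 18-fold higher number from compound 1 to compound 4 (1.27 log units; beyond the scatter), an at least 36-fold higher number from compound 3 to compound 4 (1.56 log units; beyond the scatter) and an at least 12-fold higher number from compound 2 to compound 4 (1.10 log units; beyond the scatter). The position therefore allows far larger steps than the earlier largest, a 2.9-fold lower number from compound 2 to compound 3 (0.46 log units; beyond the scatter), in this assay.

Which part of the entering group goes with this step stays open: the ethenyl link, the aromatic ring or the trifluoromethyl. Plain phenyl on the same link, or an amine or a carboxylic acid in place of trifluoromethyl, would help separate these.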